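Adding a Second Hydroxymethyl to a Fused Bicyclic Core

The compounds below may be only part of what the source reports. "The series", "measured", "known", "first", "only" and "open" are said of these compounds alone.

Three compounds share a fused two-ring core. Compound 1 `Cc1c(CO)c(CO)c2n1[C@@H](c1ccccc1)SC2` gives 12200 nM in a functional assay on MCF7 cells (Homo sapiens) for cytotoxicity, read by MTT assay, with a stated time of 24 h; a lower number here means a stronger inhibitor, a higher number a weaker inhibitor. Compound 2 `Cc1c(CO)cc2n1CSC2` gives 186000 nM in this assay. Compound 3 `Cc1cc(CO)c2n1CSC2` gives 75900 nM, the second highest of the three numbers: compound 2 lies beyond the scatter on the weaker side, compound 1 beyond it on the stronger side. Compound 4 `Cc1c(CO)c(CO)c2n1CSC2` has not yet been tested. It differs from compound 3 by hydroxymethyl in place of hydrogen on an aromatic carbon. Compound 1 also carries this group, but differs in a further place too, so no single step is shown. Compound 4 is expected to gain somewhat, a step of a 1.9-fold lower number from compound 3 to compound 4 (0.28 log units; within the scatter) beyond the scatter, giving an estimated 40000 nM (range 12000 nM to 130000 nM).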

Compound 4, half-maximal inhibitory concentration: 37800 nM
For compound 4 the middle estimate is 1.1-fold (0.02 log units) above the measured one; the range from low to high includes it.
By their numbers in this assay, from the lowest: compound 1; then compounds 4 and 3 (each within the scatter of the next); then compound 2.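

On this aromatic carbon, a second hydroxymethyl makes no change beyond the scatter in this assay (a 2.0-fold lower number from compound 3 to compound 4 (0.30 log units; within the scatter)). Added to a different aromatic carbon, the same group gives a modest step that does clear the scatter (a 4.9-fold lower number from compound 2 to compound 4 (0.69 log units; beyond the scatter)). The new compound also isolates the phenyl on the saturated ring carbon: replacing it with hydrogen gives a modest weakening (a 3.1-fold higher number from compound 1 to compound 4 (0.49 log units; beyond the scatter)).

No evidence here explains these steps. As far as these compounds go, whether an amine, a carboxylic acid or a longer chain on this aromatic carbon would move the number further remains open.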